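A carbamoyl swap on compound 2

The source may report more compounds than this note shows. Statements on the series, on what has been measured and on what is new or still open speak of the compounds shown alone.

In a functional assay on PC-3 cells (Homo sapiens) for inhibition, read by MTT assay, with a stated time of 48 h (a lower number here means a stronger inhibitor, a higher number a weaker inhibitor), compound 1 `COc1ccc(C(=O)CSc2nnc(-c3cc(OC)c(OC)c(OC)c3)n2-c2ccc(N(C)C)cc2)cc1` gives 22000 nM and compound 2 `COc1cc(-c2nnc(SCC(=O)c3ccc(F)cc3)n2-c2ccc(N(C)C)cc2)cc(OC)c1OC` gives 42300 nM, so compound 2 stands level with compound 1 within the scatter. Compound 3 `COc1cc(-c2nnc(SCC(=O)Nc3ccc(Cl)cc3)n2-c2ccc(N(C)C)cc2)cc(OC)c1OC` differs from compound 2 by (4-chlorophenyl)amino in place of 4-fluorophenyl on a carbonyl carbon. For the measured compounds named here, only one measured step bears on this, and only loosely: a 1.9-fold higher number from compound 1 to compound 2 (0.28 log units; within the scatter), for fluoro in place of methoxy on an aromatic carbon. Going by the values given here, no measured step changes the carbonyl link itself. The estimated change, a 1.4-fold lower number from compound 2 to compound 3 (0.15 log units; within the scatter), therefore stays within the scatter. Compound 3 is expected at 30000 nM, with an estimated range of 10000 nM to 80000 nM.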

Compound 3, half-maximal inhibitory concentration: > 60000 nM
Compound 3 was reported as a limit; the forecaster's own chance of this, stated with the estimate: 15%; middle value at least 2.0-fold (0.30 log units) away from the limit.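

Compound 3 is reported in this assay as a limit and not as a number: the limit of > 60000 nM in this assay, at which 1 of the 3 values shown sits.

On this carbonyl carbon, (4-chlorophenyl)amino in place of 4-fluorophenyl gives an at least 1.4-fold higher number from compound 2 to compound 3 (0.15 log units; that floor lies within the scatter), a floor that does not separate the two compounds. In place of 4-methoxyphenyl, the same group gives an at least 2.7-fold higher number from compound 1 to compound 3 (0.43 log units; beyond the scatter), the only step shown that lies beyond the scatter.

As far as these compounds go, it remains open whether the step follows the amide hydrogen or the chlorine, which enter together. A (4-fluorophenyl)amino or a methyl(4-chlorophenyl)amino group on this carbonyl carbon would separate the two.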